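The source may hold more compounds than are shown below. What is called first, only, known or untested is meant among the compounds shown, and "the series" means these compounds.

Measured so far:
compound 1, `COc1cccc(-c2nc(SC)nc3sc(C(=O)N(C)C(C)(C)C)c(N)c23)c1`: in a functional assay on HEK293 cells for agonist activity at Thyrotropin receptor (Homo sapiens), read by cAMP accumulation (a higher number here means a larger maximal response, a lower number a smaller maximal response), compound 1 gives 3.6%.
compound 2, `CSc1nc(-c2cccc(F)c2)c2c(N)c(C(=O)NC(C)(C)C)sc2n1`: in this assay compound 2 gives 8.1%.

Compound 1 holds the lower of the two numbers, but the gap to compound 2 lies within the scatter, so the two values show the same thing: a small maximal response for both. Compound 3, `COc1cccc(-c2nc(SC)nc3sc(C(=O)NCCO)c(N)c23)c1`, is not yet measured in this assay. It differs from compound 1 in one place: (2-hydroxyethyl)amino in place of methyl(tert-butyl)amino on a carbonyl carbon. Among the measured compounds shown here, no pair of measured compounds carries this kind of change, so its size cannot be read from the series. With both measured values low and close to each other, a step no larger than the scatter is expected, in either direction; the estimated step is a number 2.4 percentage points higher from compound 1 to compound 3 (within the scatter). Compound 3 is expected to give 6% in this assay, with a range from 0% to 20%.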

Compound 3, largest response reached (reported as efficacy), in percent of the reference or control that the assay uses: 2.9%
Compound 3: the middle estimate sits 3.1 percentage points above what was measured; the measured number falls inside the stated range.
By their numbers in this assay, from the lowest: compounds 3, 1 and 2 (each within the scatter of the next).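

Among the compounds shown here, the change on the carbonyl carbon gives a number 0.7 percentage points lower from compound 1 to compound 3 (within the scatter) in this assay, the first step that can be read. Exchanging methyl(tert-butyl)amino, which has no hydrogen-bond donors, for the smaller (2-hydroxyethyl)amino, which has hydrogen-bond donors and an acceptor, therefore leaves the maximal response low and does not separate the two compounds. No measurement bearing on the cause of this outcome is available.

Going by these compounds, whether a carboxylic acid, an aminoethyl chain or a longer hydroxyalkyl chain on this carbonyl carbon would give a step beyond the scatter remains open. A single step between two low values also leaves open whether any group at this position can raise the response in this assay.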